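The source may report more compounds than this note shows. Statements on the series, on what has been measured and on what is new or still open speak of the compounds shown alone.

Of the compounds shown here, two sharing one core have been tested in a functional assay on MCF7 cells (Homo sapiens) for inhibition, read by MTT assay, with a stated time of 24 h; a higher number here means a weaker inhibitor, a lower number a stronger inhibitor. Compound 1 `CCOC(=O)c1c(C)[nH]c(=O)c(C#N)c1-c1ccc(C)cc1` gives 8000 nM. Compound 2 `CCOC(=O)c1c(C)[nH]c(=O)c(C#N)c1-c1ccc([N+](=O)[O-])cc1`, in this assay, gives 82000 nM. Within the data shown here, the single measured step between them, a 10-fold higher number from compound 1 to compound 2 (1.01 log units; beyond the scatter), follows from putting nitro in place of methyl on an aromatic carbon. Among the measured compounds shown here, compound 2 therefore stands at the highest of the two numbers known so far, with compound 1 well below it and the gap beyond the usual scatter.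

Compound 3 `CCOC(=O)c1c(C)[nH]c(=O)c(C#N)c1-c1ccc(F)cc1` is the next compound, and it differs from compound 2 by fluoro in place of nitro on an aromatic carbon. For the measured compounds named here, the only measured step that bears on this change is the one from compound 1 to compound 2, which was large and ran toward a weaker inhibitor as nitro arrived. Going by the values given here, with nitro leaving again, a step in the opposite direction is expected, most of the way back toward compound 1 but with some uncertainty, since fluoro is not methyl and no fluoro compound has been measured here. Compound 3 is thus expected to give 15000 nM in this assay, within a range from 5000 nM to 50000 nM, meaning an expected step of a 5.5-fold lower number from compound 2 to compound 3 (0.74 log units; beyond the scatter).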

Compound 3, half-maximal inhibitory concentration: 22900 nM
Compound 3: middle estimate off by 1.5-fold (0.18 log units), on the low side, within the range that was stated.
By their numbers in this assay, from the lowest: compound 1; then compound 3; then compound 2.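

With a third group at this place on the aromatic ring, para to a large group, the picture in this assay no longer rests on a single pair: fluoro in place of nitro gives a 3.6-fold lower number from compound 2 to compound 3 (0.55 log units; beyond the scatter) and fluoro in place of methyl gives a 2.9-fold higher number from compound 1 to compound 3 (0.46 log units; beyond the scatter) in the same series. Compound 3 therefore sits between the other two, with both gaps beyond the usual scatter, so nitro is not simply an outlier against everything else, and changing this one group can shift the number by intermediate amounts as well as by a large one. Nothing shown here accounts for the order of methyl, fluoro and nitro, since no measurement beyond these inhibition numbers accompanies them.

Among these compounds, with only three groups at this place, it remains open whether an amine, a methoxy group or plain hydrogen would land near compound 1, near compound 2 or outside that span altogether. Also open, on these data alone, is whether a carboxylic acid in place of the ester on the shared core would move all three numbers alike or would change their order.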